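Adding methylsulfanyl to the thiourea phenyl of compound 3

A few compounds are considered here, and "the series" means these few. Any claim that something is new, unique, unknown or untested is made for them only; others in the source may bear on it.

Measured compounds:
- compound 1, `NC(=O)c1c(NC(=O)c2ccccc2Cl)sc2c1CCN(Cc1ccccc1F)C2`, 21800 nM
- compound 2, `NC(=O)c1c(NC(=O)c2ccccc2Cl)sc2c1CCN(Cc1ccc([N+](=O)[O-])cc1)C2`, 11400 nM
- compound 3, `NC(=O)c1c(NC(=O)c2ccccc2Cl)sc2c1CCN(C(=S)Nc1ccccc1)C2`, 5940 nM

These three share one core and differ only in the group on the amine nitrogen in the ring. In a functional assay on HL-60 cells (Homo sapiens) for antiproliferative activity, with a stated time of 24 h (on this read-out higher numbers stand for weaker inhibition and lower numbers for stronger inhibition), compound 3 gives the lowest of the three numbers, with a 3.7-fold lower number from compound 1 to compound 3 (0.56 log units; beyond the scatter) and, nearer, a 1.9-fold lower number from compound 2 to compound 3 (0.28 log units; within the scatter). Compound 4, `CSc1ccccc1NC(=S)N1CCc2c(sc(NC(=O)c3ccccc3Cl)c2C(N)=O)C1`, keeps the whole of compound 3 and changes one point: methylsulfanyl in place of hydrogen on an aromatic carbon. For the measured compounds named here, no measured step touches this phenyl; the steps seen, a 1.9-fold lower number from compound 1 to compound 2 (0.28 log units; within the scatter) and the two above, all swap the entire group on the ring nitrogen rather than decorate it, so they give only a loose guide. With the core and the thiourea unchanged, the expectation for compound 4 in this assay is a value close to that of compound 3, with a 1.2-fold lower number from compound 3 to compound 4 (0.07 log units; within the scatter) expected to lie within the scatter. Compound 4 is therefore estimated at 5000 nM, with a range from 2000 nM to 15000 nM.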

Compound 4, half-maximal inhibitory concentration: 14600 nM
Beside the measured number, compound 4's estimate is 2.9-fold (0.47 log units) below it, and the stated range covers the measured number.
By their numbers in this assay, from the lowest: compounds 3, 2, 4 and 1 (each within the scatter of the next, the first and the last beyond it).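

Decorating the thiourea phenyl is not neutral in this assay: methylsulfanyl in place of hydrogen, on an aromatic carbon and ortho to a large group, moves the result towards weaker inhibition (a 2.5-fold higher number from compound 3 to compound 4 (0.39 log units; beyond the scatter)). The gap that separated the thiourea compound 3 from the benzyl-type compound 1 also closes (a 1.5-fold lower number from compound 1 to compound 4 (0.17 log units; within the scatter)), and the other comparison shows no separation either (a 1.3-fold higher number from compound 2 to compound 4 (0.11 log units; within the scatter)), so compound 4 cannot be told apart from either compound. No measured evidence here accounts for this shift.

The compounds shown leave open whether this loss belongs to methylsulfanyl itself or would also follow from another group at this place, such as methoxy, chloro or an amine. They also leave open whether methylsulfanyl on a different carbon of the same phenyl would give a similar number.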